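The source may hold more compounds than are shown below. What is called first, only, known or untested is meant among the compounds shown, and "the series" means these compounds.

In a functional assay (on this read-out lower numbers stand for stronger inhibition and higher numbers for weaker inhibition), compound 1 (`CC(C)=CCOc1cc(O)c2c(c1)OC(c1ccccc1F)CC2=O`) gives 5300 nM while compound 2 (`CC(C)=CCOc1cc(O)c2c(c1)OC(c1ccccc1Cl)CC2=O`) gives 4270 nM and compound 3 (`CC(C)=CCOc1cc(O)c2c(c1)OC(c1cccc(Cl)c1)CC2=O`) gives 6060 nM which lies within the scatter of both others. Compound 4 (`CC(C)=CCOc1cc(O)c2c(c1)OC(c1ccc(Br)cc1)CC2=O`) carries 4-bromophenyl in place of 3-chlorophenyl on a saturated ring carbon. The measured steps that bear on this change are small and all within the scatter: (a 1.1-fold higher number from compound 1 to compound 3 (0.06 log units; within the scatter)) and (a 1.4-fold higher number from compound 2 to compound 3 (0.15 log units; within the scatter)) for exchanges of the aryl group, and (a 1.2-fold lower number from compound 1 to compound 2 (0.09 log units; within the scatter)) for chloro in place of fluoro. Among the compounds with values here, no measured compound carries a 4-bromophenyl group. No step beyond the scatter is therefore expected in this assay and the expected step is (a 1.2-fold lower number from compound 3 to compound 4 (0.08 log units; within the scatter)) for now. Compound 4 is expected at 5000 nM with an estimated range from 2500 nM to 10500 nM on this read-out.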

Compound 4, half-maximal inhibitory concentration: 2770 nM
Compound 4: the middle estimate sits 1.8-fold (0.26 log units) above what was measured, within the range that was stated.
By their numbers in this assay, from the lowest: compounds 4, 2, 1 and 3 (each within the scatter of the next, the first and the last beyond it).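

In this assay, the aryl group on the saturated ring carbon next to the ring oxygen now yields a step beyond the scatter (a 2.2-fold lower number from compound 3 to compound 4 (0.34 log units; beyond the scatter)), which no earlier exchange did. The other two steps stay within the scatter (a 1.5-fold lower number from compound 2 to compound 4 (0.19 log units; within the scatter)) (a 1.9-fold lower number from compound 1 to compound 4 (0.28 log units; within the scatter)), so compound 4 separates only from compound 3. This exchange alters both the halogen and its place on the phenyl ring, so the step cannot be assigned to either alone. A 4-chlorophenyl or 3-bromophenyl group at this carbon would separate the two. No data on hand give a reason for the step.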